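This account rests on a few compounds, and the source may have more. Where it says the series, first, only, none or still open, it means among the compounds named here.

Measured so far:
- compound 1, `CCCc1nc(C(C)(C)O)c(C(=O)NCCCCCC[N+](=O)[O-])n1Cc1ccc(-c2ccccc2C2=NNNN2)cc1`: 101%
- compound 2, `CCCc1nc(C(C)(C)O)c(C(=O)NCCNCCO)n1Cc1ccc(-c2ccccc2C2=NNNN2)cc1`: 98.9%
- compound 3, `CCCc1nc(C(C)(C)O)c(C(=O)NCCCCCCC(=O)O)n1Cc1ccc(-c2ccccc2C2=NNNN2)cc1`: 97.5%

In an ADME assay on a cell-free system (plasma, Rattus norvegicus, strain Sprague-Dawley) for metabolic stability, with a stated time of 30 min, tested at 50 mg/mL (a higher number here means that more of the compound is left, a lower number that less of the compound is left), compound 1 gives 101% and holds the highest of the three numbers, though the two neighbours are within the scatter of it: a number 2.1 percentage points lower from compound 1 to compound 2 (within the scatter) and a number 3.5 percentage points lower from compound 1 to compound 3 (within the scatter). Between the other two, a number 1.4 percentage points lower from compound 2 to compound 3 (within the scatter). For the measured compounds named here, all three measured compounds therefore sit close to full recovery in this assay, and none of the measured steps moves the number beyond the scatter.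

Compound 4 is `CCCc1nc(C(C)(C)O)c(C(=O)OCCCCCCC(=O)O)n1Cc1ccc(-c2ccccc2C2=NNNN2)cc1`. It differs from compound 1 as follows: (6-carboxyhexyl)oxy in place of (6-nitrohexyl)amino on a carbonyl carbon. One part of this change has a measured counterpart: the step of a number 3.5 percentage points lower from compound 1 to compound 3 (within the scatter) covers the carboxy in place of nitro on the chain and is within the scatter. Going by the values given here, the other part, the chain now attached through oxygen instead of an amide-type nitrogen on the carbonyl carbon, has no measured counterpart among the three compounds, so the data give no direct guide to its size or direction.

Taking the measured step as the only anchor, no step beyond the scatter is expected, but the range is kept wide for the unmeasured part of the change. Compound 4 is expected to give 92% in this assay, with a range of 70% to 102%. This estimate means a step of a number 9 percentage points lower from compound 1 to compound 4 (within the scatter), which is expected to lie within the scatter.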

Compound 4, percent of the compound remaining: 98.8%
For compound 4 the middle estimate is 6.8 percentage points below the measured one; the range from low to high includes it.
By their numbers in this assay, from the lowest: compounds 3, 4, 2 and 1 (each within the scatter of the next).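

In this assay, the link to the carbonyl carbon now has a measured step of its own: (6-carboxyhexyl)oxy in place of (6-carboxyhexyl)amino gives a number 1.3 percentage points higher from compound 3 to compound 4 (within the scatter), so exchanging the amide-type nitrogen for oxygen, with the chain and its carboxy end unchanged, does not move the number beyond the scatter. The broader replacements on the same carbonyl carbon read alike, with a number 2.2 percentage points lower from compound 1 to compound 4 (within the scatter) and with a number 0.1 percentage points lower from compound 2 to compound 4 (within the scatter), so the oxygen link joins the nitro, carboxy and (2-hydroxyethyl)amino chain ends among the changes at this position that stay within the scatter.

Still open, going by these compounds, is whether any group on this carbonyl carbon can take the number beyond the scatter, for example a hydroxy group in place of the whole chain, a much shorter chain, or a longer chain ending in a primary amine. On these data alone, it is also open whether an oxygen-linked chain with a nitro or (2-hydroxyethyl)amino end would read the same way as the carboxy-ended one.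

Nothing available here gives a reason for how closely these numbers sit together.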